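From benzofuran to ethynyl on a shared core

The source may report more compounds than this note shows. Statements on the series, on what has been measured and on what is new or still open speak of the compounds shown alone.

Values in a functional assay on CCRF-CEM cells (Homo sapiens), read by MTT assay, with a stated time of 72 h; on this read-out higher numbers stand for weaker inhibition and lower numbers for stronger inhibition:
Compound 1 `Cc1nc(N)c2c(-c3ccco3)cn([C@@H]3O[C@H](CO)[C@@H](O)[C@H]3O)c2n1`: > 100000 nM
Compound 2 `Cc1nc(N)c2c(-c3ccccc3)cn([C@@H]3O[C@H](CO)[C@@H](O)[C@H]3O)c2n1`: > 20000 nM
Compound 3 `Cc1nc(N)c2c(-c3cc4ccccc4o3)cn([C@@H]3O[C@H](CO)[C@@H](O)[C@H]3O)c2n1`: > 20000 nM
Compound 4 `C#Cc1cn([C@@H]2O[C@H](CO)[C@@H](O)[C@H]2O)c2nc(C)nc(N)c12`: not yet measured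

None of the three measured compounds has a number in this assay, and each entry is a limit of the assay. Compound 3 stands at a limit, > 20000 nM. That limit is the limit of > 20000 nM in this assay, at which 2 of the 3 values shown sit. The limit of compound 1 is the other one seen here: the limit of > 100000 nM in this assay, at which 1 of the 3 values shown sits.

The next change is ethynyl in place of 1-benzofuran-2-yl on an aromatic carbon of the shared core (ethynyl in place of 1-benzofuran-2-yl on an aromatic carbon). Three measured changes of the group at this same place bear on it. These are a step that the two limits leave unreadable from compound 1 to compound 2, a step that the two limits leave unreadable from compound 1 to compound 3 and a step that the two limits leave unreadable from compound 2 to compound 3. All three have limits at both ends, so they give no size and no direction. Within the data shown here, none of the measured compounds carries ethynyl, so the data offer no direct guide to this group.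

Compound 3 at > 20000 nM remains the only anchor, and it supports no large move. The expected change is an at least 1.3-fold lower number from compound 3 to compound 4 (0.12 log units; that floor lies within the scatter), a modest and uncertain shift towards stronger inhibition. For compound 4 the estimated value is 15000 nM, with an expected range from 2000 nM to 100000 nM.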

Compound 4, half-maximal inhibitory concentration: > 20000 nM
Compound 4 was reported as a limit; the forecaster's own chance of this, stated with the estimate: 50%; middle value at least 1.3-fold (0.12 log units) away from the limit.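

In this assay compound 4 gives > 20000 nM, which is a limit of the assay and not a number. Compound 1, compound 2 and compound 3 also stand at limits, so none of their steps to compound 4 can be read. The compounds shown leave open whether any of these four groups gives a measurable value in this assay, and how the groups rank.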